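A few compounds are considered here, and "the series" means these few. Any claim that something is new, unique, unknown or untested is made for them only; others in the source may bear on it.

Compound 1, `COc1cc(Cl)cc(-c2nn(-c3cccc(NC(=O)Nc4cc(C(F)(F)F)cc(C(F)(F)F)c4)c3)cc2-c2ccncc2)c1`, in a functional assay on SNB-75 cells (Homo sapiens) for inhibition, read by sulforhodamine B assay, with a stated time of 48 h, tested at 0.1 uM (a higher number here means a weaker effect of the compound at the concentration tested, a lower number a stronger effect), gives 74%.
Compound 2, `COc1cc(Cl)cc(-c2nn(-c3cccc(NC(=O)Nc4ccc(Cl)c(Cl)c4)c3)cc2-c2ccncc2)c1`, in this assay gives 90%.

Going by the values given here, of the two compounds measured so far, compound 2 stands at the highest number, which in this reading means the weaker effect; the gap to compound 1 is wider than the usual scatter of such measurements, so the difference between the two is taken as real.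

Compound 3, `COc1cc(Cl)cc(-c2nn(-c3cccc(NC(=O)Nc4cccc(C(F)(F)F)c4)c3)cc2-c2ccncc2)c1`, has not yet been measured. Its structure differs from compound 2 by one change: 3-(trifluoromethyl)phenyl in place of 3,4-dichlorophenyl on an amide-type nitrogen. Among the compounds with values here, no step between measured compounds describes this particular exchange, so nothing firm can be carried over from the pair already in hand, and the only guidance is that compound 1, which carries trifluoromethyl groups rather than chlorines on the same ring, gives 74%.

Compound 3 is therefore expected to move toward a lower number than compound 2, by a step estimated at a number 8 percentage points lower from compound 2 to compound 3 (within the scatter). The estimate for compound 3 in this assay is 82%, with a range from 66% to 98%.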

Compound 3, a percentage reported as activity, at one concentration (the size of the read-out at that concentration, not a potency): 55%
Compound 3: the middle estimate sits 27 percentage points above what was measured; measured number outside the range, below it.
By their numbers in this assay, from the lowest: compound 3; then compound 1; then compound 2.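

In this assay the exchange of 3,4-dichlorophenyl for 3-(trifluoromethyl)phenyl on an amide-type nitrogen gives a number 35 percentage points lower from compound 2 to compound 3 (beyond the scatter), a large move toward the stronger effect, which shows that the effect at this concentration depends strongly on the group at this place. Hydrogen in place of trifluoromethyl on an aromatic carbon gives a number 19 percentage points lower from compound 1 to compound 3 (beyond the scatter), so among these two compounds the ring with one trifluoromethyl group reads stronger than the ring with two. Nothing available explains either step.

As far as these compounds go, whether a lone chlorine, a nitrile or a methoxy group on the same ring would read like the lone trifluoromethyl group remains open. Also open, from the compounds shown here alone, is whether these differences hold at other concentrations or in other cell lines.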